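Cyclopropylamino to cyclopentylamino: working notes on the series

The compounds below may be only part of what the source reports. "The series", "measured", "known", "first", "only" and "open" are said of these compounds alone.

Measured in an ADME assay on Vero cells (Chlorocebus sabaeus) for cytotoxicity, read by CellTiter-Glo, with a stated time of 72 h; a higher number here means that more compound is tolerated, a lower number that less compound is tolerated:
- compound 1 `COC(=O)/C=C/n1ccnc1[N+](=O)[O-]`: 16 ug/mL
- compound 2 `[O-][n+]1nc(NC2CC2)[n+]([O-])c2ccccc21`: 21 ug/mL

Compound 2 stands within the scatter of compound 1, so these two numbers set no order. Compound 3 `[O-][n+]1nc(NC2CCCC2)[n+]([O-])c2ccccc21` carries cyclopentyl in place of cyclopropyl on a nitrogen on an aromatic ring. Among the compounds with values here, no measured pair shows this change, so this assay offers only compound 2 at 21 ug/mL as an anchor, and no step beyond the scatter is expected. The expected change is a 1.2-fold lower number from compound 2 to compound 3 (0.07 log units; within the scatter). For compound 3 the estimated value is 18 ug/mL, with an expected range of 7 ug/mL to 40 ug/mL.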

Compound 3, half-maximal cytotoxic concentration: 10 ug/mL
Compound 3: middle estimate off by 1.8-fold (0.26 log units), on the high side; low and high end bracket the measured number.
By their numbers in this assay, from the lowest: compounds 3, 1 and 2 (each within the scatter of the next, the first and the last beyond it).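

In this assay, the series gains its first step beyond the scatter: cyclopentyl in place of cyclopropyl on a nitrogen on an aromatic ring gives a 2.1-fold lower number from compound 2 to compound 3 (0.32 log units; beyond the scatter). The number therefore responds to the ring carried at this position, although the step is modest. Nothing at hand accounts for the step.

Going by these compounds, whether the number follows ring size stays open: cyclobutyl or cyclohexyl on that nitrogen would test this. On these data alone, how an open chain such as isopropyl, or a morpholine ring, would read at this position also remains open.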